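The compounds below may be only part of what the source reports. "The series", "measured", "known", "first", "only" and "open" are said of these compounds alone.

Measured compounds:
Compound 1 `O=c1ccn(CCCOC(c2ccccc2)(c2ccccc2)c2ccccc2)c(=O)[nH]1` — in an assay on isolated protein for inhibition of Deoxyuridine 5'-triphosphate nucleotidohydrolase, mitochondrial (Homo sapiens) (on this read-out lower numbers stand for stronger inhibition and higher numbers for weaker inhibition), compound 1 gives 313000 nM.
Compound 2 `O=c1ccn(CCCO)c(=O)[nH]1` — in this assay compound 2 gives > 1000000 nM; this is a limit of the assay, not a number (the limit of > 1000000 nM in this assay, at which 1 of the 3 values shown sits).
Compound 3 `O=c1ccn(CCCCCCOC(c2ccccc2)(c2ccccc2)c2ccccc2)c(=O)[nH]1` — in this assay compound 3 gives 476000 nM.

Among the two numbers that are not limits, compound 1 has the lowest; compound 3 lies closest to it, and the step of a 1.5-fold higher number from compound 1 to compound 3 (0.18 log units; within the scatter) stays within the scatter, so the two cannot be told apart. Going by the values given here, the only structural change measured so far is thus the lengthening of the chain between the shared core and the trityl ether, which left the read-out essentially unchanged.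

Compound 4 `O=c1ccn(CC(CCO)COC(c2ccccc2)(c2ccccc2)c2ccccc2)c(=O)[nH]1` is not yet measured. It differs from compound 1 by 2-hydroxyethyl in place of hydrogen on a saturated chain carbon bound to two saturated chain carbons. Among the compounds with values here, no measured step tests a branch of this kind; the closest evidence is the chain-length step, which was flat. Compound 1 and compound 3 are both weak in this assay, and the branch adds a small polar group to the same chain.

The expectation is therefore a step of a 1.3-fold higher number from compound 1 to compound 4 (0.11 log units; within the scatter), that is, no movement beyond the scatter. Compound 4 is estimated at 400000 nM, with a range from 150000 nM to 1000000 nM.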

Compound 4, inhibition constant: 21000 nM
The estimate for compound 4 lay 19-fold (1.28 log units) above the measured number; measured number below the stated range.
By their numbers in this assay, from the lowest: compound 4; then compounds 1 and 3 (each within the scatter of the next). At a limit, above all of these: compound 2.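

In this assay, the saturated chain carbon bound to two saturated chain carbons proves to be a sensitive place: 2-hydroxyethyl in place of hydrogen there gives a 15-fold lower number from compound 1 to compound 4 (1.17 log units; beyond the scatter) and is a large change for a single added branch. Going by these compounds alone, the only earlier change to this chain, its lengthening, gave just a 1.5-fold higher number from compound 1 to compound 3 (0.18 log units; within the scatter) and so offered no sign that the chain could respond at all; among the compounds with numbers, adding this branch matters where adding chain length did not. Nothing shown gives a measured reason for the gain, so the result records what happens at this position and not how it comes about.

Going by these compounds, it remains open whether the gain depends on the hydroxyl group at the end of the branch or on its two carbons alone, a question that a plain ethyl branch would help to separate from the effect of the hydroxyl. Also open, on these data alone, are whether an amine, a carboxylic acid or a longer chain in the same place would lower the number further, and whether the same branch would give a similar step on the longer chain of compound 3.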